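A few compounds are considered here, and "the series" means these few. Any claim that something is new, unique, unknown or untested is made for them only; others in the source may bear on it.

Measured compounds:
Compound 1, `C[Se]/C(=N\C(=O)c1ccco1)NC(=O)c1ccco1`, gives > 100000 nM in a functional assay on HepG2 cells (Homo sapiens) for cytotoxicity, read by MTT assay, with a stated time of 72 h; a lower number here means that less compound is tolerated, a higher number that more compound is tolerated.
Compound 2, `C[Se]/C(=N\C(=O)c1cc(-c2ccccc2)nc2ccccc12)NC(=O)c1cc(-c2ccccc2)nc2ccccc12`, gives 65400 nM in this assay.

Compound 1 stands only at a limit of this assay: the value is not a number but the top of what was tested, as the limit of > 100000 nM in this assay, at which 1 of the 2 values shown sits, records. Among the compounds with values here, compound 2 carries a different core and is the one compound of the pair that yields a real number; no step between compound 1 and compound 2 is available, since they differ in more than one place, and the two values show only that compound 2 is tolerated less well than the limit reached by compound 1.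

Compound 3, `O=C(/N=C(/NC(=O)c1ccco1)[Se]Cc1ccccc1)c1ccco1`, differs from compound 1 by phenyl in place of hydrogen on a saturated chain carbon bound to a selenium atom. Within the data shown here, no measured step of this kind exists, so the size of the change can only be guessed. The step from compound 1 to compound 3 is expected to be small, an at least 1.2-fold lower number from compound 1 to compound 3 (0.09 log units; that floor lies within the scatter), with a slight lean toward less compound being tolerated. Compound 3 is therefore expected at 80000 nM, with a range from 30000 nM to 250000 nM.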

Compound 3, concentration lethal to 50% of the cells: 76500 nM
Compound 3: middle estimate off by 1.0-fold (0.02 log units), on the high side; measured number inside the range.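

Within the data shown here, compound 3 gives the first real number for a change at this position in this assay: with benzyl in place of methyl on the core of compound 1, compound 3 gives 76500 nM. The change, phenyl in place of hydrogen on a saturated chain carbon bound to a selenium atom, reads as an at least 1.3-fold lower number from compound 1 to compound 3 (0.11 log units; that floor lies within the scatter), so the floor alone does not establish a shift beyond the usual scatter, and the true step may be larger. Only a floor can be read for this step because compound 1 carries a limit and not a number: the limit of > 100000 nM in this assay, at which 1 of the 3 values shown sits.

Still open, as far as these compounds go, is how far the number really moves from methyl to benzyl, and whether the same change on the core of compound 2 would give a step of similar size. Also open, from the compounds shown here alone, is what a longer chain such as phenethyl, or a chain ending in an amine or a carboxylic acid, would do on this saturated chain carbon bound to a selenium atom.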